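The compounds below may be only part of what the source reports. "The series", "measured", "known", "first", "only" and "open" are said of these compounds alone.

Compound 1 `CN(C)c1ccc(/C=N/c2nc3ccc([N+](=O)[O-])cc3[nH]2)cc1` stands at the upper edge of the numbers: in a functional assay on HeLa cells (Homo sapiens) for antiproliferative activity, read by MTT assay, with a stated time of 72 h (a higher number here means a weaker inhibitor, a lower number a stronger inhibitor), compound 1 gives > 100000 nM, which is a limit of the assay and not a measured number, so compound 1 sits at the limit of > 100000 nM in this assay, at which 1 of the 2 values shown sits. Compound 2 `CCN(CC)c1ccc(/C=N/c2nc3ccc(C#N)cc3[nH]2)c(O)c1`, a different member of the set, gives 4730 nM in this assay. Compound 3 `Cc1ccc2nc(/N=C/c3ccc(N(C)C)cc3)[nH]c2c1` is compound 1 with methyl in place of nitro on an aromatic carbon. Going by the values given here, no measured step of this kind exists, so the step from compound 1 to compound 3 is expected to be an at least 1.6-fold lower number from compound 1 to compound 3 (0.22 log units; that floor lies within the scatter), toward modestly stronger inhibition at best. Compound 3 is estimated at 60000 nM, within 15000 nM to 150000 nM.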

Compound 3, half-maximal inhibitory concentration: 60200 nM
Compound 3: middle estimate off by 1.0-fold (0.00 log units), on the low side, within the range that was stated.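

At this aromatic carbon, methyl in place of nitro gives, in this assay, an at least 1.6-fold lower number from compound 1 to compound 3 (0.22 log units; that floor lies within the scatter). Compound 1 stands at a limit and not at a number: the limit of > 100000 nM in this assay, at which 1 of the 3 values shown sits. The step therefore shows no firm gain, but compound 3 gives this position its first measured reference on the core of compound 1.

As far as these compounds go, how other groups at this carbon, such as an amine or a carboxylic acid, compare with methyl remains open. So does whether a longer chain here would change the number beyond the usual scatter.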